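A few compounds are considered here, and "the series" means these few. Any claim that something is new, unique, unknown or untested is made for them only; others in the source may bear on it.

Measured compounds:
- compound 1 `CCn1c(C(=O)NCCO)ccc1C(CC)(CC)c1ccc(OCC(O)C(C)(C)C)c(C)c1`: in an assay on HL-60 cells for agonist activity at vitamin D3 receptor (Homo sapiens), with a stated time of 96 h (a lower number here means that less compound is needed, a higher number that more compound is needed for the effect), compound 1 gives 5640 nM
- compound 2 `CCn1c(C(=O)N[C@H](CO)CCO)ccc1C(CC)(CC)c1ccc(OCC(O)C(C)(C)C)c(C)c1`: in this assay compound 2 gives 110 nM

Within the data shown here, compound 2 stands lowest of the two numbers; the only neighbour is compound 1, and the step between them is a 51-fold lower number from compound 1 to compound 2 (1.71 log units; beyond the scatter).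

Compound 3 `CCn1c(C(=O)N[C@@H](C)C(=O)O)ccc1C(CC)(CC)c1ccc(OCC(O)C(C)(C)C)c(C)c1` is not yet measured. Its difference from compound 2: 1-carboxyethyl in place of 3-hydroxy-1-(hydroxymethyl)propyl on an amide-type nitrogen. Among the measured compounds shown here, the single measured step concerns the same amide-type nitrogen, where adding 2-hydroxyethyl gave a 51-fold lower number from compound 1 to compound 2 (1.71 log units; beyond the scatter). Compound 3 drops the whole 3-hydroxy-1-(hydroxymethyl)propyl group that carried that gain and puts 1-carboxyethyl in its place, a change without direct precedent in this pair. A higher number than compound 2 is therefore expected, though the new group is not hydrogen as in compound 1, so the estimate is left wide. For compound 3 the expected value in this assay is 1500 nM, within 250 nM to 9000 nM, which means an expected step of a 14-fold higher number from compound 2 to compound 3 (1.13 log units; beyond the scatter).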

Compound 3, half-maximal effective concentration: 4.07 nM
Compound 3: middle estimate off by 370-fold (2.57 log units), on the high side, outside the stated range (below it).
By their numbers in this assay, from the lowest: compound 3; then compound 2; then compound 1.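

At the amide-type nitrogen, the order seen so far in this assay does not depend on keeping hydroxyl groups: 1-carboxyethyl in place of 3-hydroxy-1-(hydroxymethyl)propyl gives a 27-fold lower number from compound 2 to compound 3 (1.43 log units; beyond the scatter) and, set against 2-hydroxyethyl, gives a 1400-fold lower number from compound 1 to compound 3 (3.14 log units; beyond the scatter) at this same position. Compound 3 goes against the reading of compound 1 and compound 2 alone, that a larger group with more hydrogen-bond donors at this nitrogen brings the lower number, since 1-carboxyethyl has fewer heavy atoms and fewer hydrogen-bond donors than the group it replaces. Nothing measured on these compounds accounts for the size of these steps.

Open, going by these compounds, is whether the carboxyl itself carries the gain, which a methyl ester or primary amide in its place would test. Also open, on these data alone, are the opposite configuration at the 1-carboxyethyl stereocentre and a longer chain carrying the carboxyl.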